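A few compounds are considered here, and "the series" means these few. Any claim that something is new, unique, unknown or untested is made for them only; others in the source may bear on it.

Compounds 1, 2 and 3 share one core and differ only in the aryl on the hydroxy-bearing chain: compound 1 `COc1cccc(C(O)CCn2nc3c(Br)c(Br)c(Br)c(Br)c3n2)c1`, compound 2 `OC(CCn1nc2c(Br)c(Br)c(Br)c(Br)c2n1)c1cccc(Cl)c1`, compound 3 `OC(CCn1nc2c(Br)c(Br)c(Br)c(Br)c2n1)c1ccc(Br)cc1`. In a functional assay on CCRF-CEM cells (Homo sapiens) for antiproliferative activity, read by MTT assay, with a stated time of 48 h, tested at 25 uM (a higher number here means a weaker effect of the compound at the concentration tested, a lower number a stronger effect), compound 1 gives 50%, compound 2 gives 68% and compound 3 gives 69%. Compound 3 therefore holds the highest number of the three, within the scatter of compound 2 but separated from compound 1 by a number 19 percentage points higher from compound 1 to compound 3 (beyond the scatter). Compound 4 `CC(O)CCn1nc2c(Br)c(Br)c(Br)c(Br)c2n1` differs from compound 3 by methyl in place of 4-bromophenyl on a saturated chain carbon bound to an oxygen on a saturated carbon and a saturated chain carbon. For the measured compounds named here, the steps at this place, a number 19 percentage points higher from compound 1 to compound 3 (beyond the scatter) and a number 1 percentage points higher from compound 2 to compound 3 (within the scatter), only exchange one aryl for another; no measured step removes the ring. A further modest rise is expected, a number 9 percentage points higher from compound 3 to compound 4 (within the scatter). Compound 4 is estimated at 78%, between 60% and 96%.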

Compound 4, a percentage reported as activity, at one concentration (the size of the read-out at that concentration, not a potency): 86%
For compound 4 the middle estimate is 8 percentage points below the measured one; low and high end bracket the measured number.
By their numbers in this assay, from the lowest: compound 1; then compounds 2 and 3 (each within the scatter of the next); then compound 4.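

Methyl in place of the aryl is the first change here that removes the ring from this carbon, and in this assay it weakens the effect from each aryl compound: a number 17 percentage points higher from compound 3 to compound 4 (beyond the scatter), a number 18 percentage points higher from compound 2 to compound 4 (beyond the scatter) and a number 36 percentage points higher from compound 1 to compound 4 (beyond the scatter). The ring at this position therefore goes with a stronger effect for all three aryl groups shown, though the size of the loss differs with the aryl that leaves. No measurement here bears on the reason for this. A longer chain or a cyclohexyl group at this carbon would show whether an aromatic ring is needed, or whether a larger carbon group is enough. On these data alone, an amine or a carboxylic acid on the phenyl ring also remains open.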